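The source may report more compounds than this note shows. Statements on the series, on what has been measured and on what is new or still open speak of the compounds shown alone.

Compound 1 `Cc1nc(-c2ccc(Cl)cc2)sc1C(=O)CSc1nc(-c2ccc(Cl)c(Cl)c2)c(C#N)c(=O)[nH]1` and compound 2 `Cc1nc(-c2ccc(Cl)cc2)sc1C(=O)CSc1nc(-c2cccc(Cl)c2)c(C#N)c(=O)[nH]1` were both tested in an ADME assay on HEK293 cells (Homo sapiens) for cytotoxicity, read by MTT assay, with a stated time of 48 h; a lower number here means a stronger inhibitor, a higher number a weaker inhibitor. Compound 1 gives 46900 nM there, and compound 2 gives 30100 nM. The step between them is a 1.6-fold lower number from compound 1 to compound 2 (0.19 log units; within the scatter), the change being (hydrogen in place of chloro on an aromatic carbon).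

Compound 3 `Cc1nc(-c2ccccc2)sc1C(=O)CSc1nc(N)c(C#N)c(-c2ccc(Cl)cc2)n1` carries a different core; the difference between the two cores is not broken down here. In this assay compound 3 is reported as "not determined" (no result reported), so no number is available for it. Compound 4 `Cc1nc(-c2ccccc2)sc1C(=O)CSc1nc(N)c(C#N)c(-c2ccccc2)n1` is to be measured in this assay; it differs from compound 3 by hydrogen in place of chloro on an aromatic carbon. This is the same kind of change as that from compound 1 to compound 2, though the surroundings differ: in compound 1 the chloro that leaves sits ortho to a chloro group, and this is not so in compound 3.

With no number for compound 3, the expectation for compound 4 rests on compound 1 at 46900 nM and compound 2 at 30100 nM, both weak, and on the same kind of change having moved only within the scatter. Compound 4 is therefore expected to give about 35000 nM in this assay, most likely between 10000 nM and 100000 nM.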

Compound 4, half-maximal inhibitory concentration: 46700 nM
Compound 4: the middle estimate sits 1.3-fold (0.13 log units) below what was measured; measured number inside the range.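

Compound 3 has no number in this assay, so the step from compound 3 to compound 4, 4-chlorophenyl to phenyl, cannot be read. The compounds shown leave open whether this change moves the reading at all on the core that compound 3 and compound 4 share. No supporting evidence bears on this result.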